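Moving a methyl group around the shared core

The compounds below may be only part of what the source reports. "The series", "measured", "known", "first", "only" and "open" are said of these compounds alone.

Compound 1 `CC(C)(C)OC(=O)N1CCC(CCOC(=O)N2CCc3cc(S(C)(=O)=O)ccc32)CC1`: in a functional assay on CHO cells for agonist activity at Glucose-dependent insulinotropic receptor (Homo sapiens), read by a luciferase reporter and cAMP accumulation, with a stated time of 2 h (on this read-out lower numbers stand for an effect already at smaller amounts and higher numbers for an effect only at larger amounts of compound), compound 1 gives 68 nM.
Compound 2 `Cc1c(S(C)(=O)=O)ccc2c1CCN2C(=O)OCCC1CCN(C(=O)OC(C)(C)C)CC1`: in this assay compound 2 gives 770 nM.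
Compound 3 `CC(C)(C)OC(=O)N1CCC(CCOC(=O)N2CCc3cc(S(C)(=O)=O)c(F)cc32)CC1`: in this assay compound 3 gives 160 nM.

Among these three, compound 1 stands at the lowest number; compound 3 is nearest to it and compound 2 furthest. Compound 4 `Cc1cc(S(C)(=O)=O)cc2c1N(C(=O)OCCC1CCN(C(=O)OC(C)(C)C)CC1)CC2` differs from compound 1 by methyl in place of hydrogen on an aromatic carbon. Among the measured compounds shown here, two measured steps bear on this change. The closest is an 11-fold higher number from compound 1 to compound 2 (1.05 log units; beyond the scatter), the same methyl group placed at another aromatic carbon of the shared core; the other is a 2.4-fold higher number from compound 1 to compound 3 (0.37 log units; beyond the scatter), a smaller group at yet another carbon. Both steps went toward higher numbers, so a rise beyond the scatter is expected for compound 4 in this assay, likely a 4.4-fold higher number from compound 1 to compound 4 (0.64 log units; beyond the scatter). The estimate for compound 4 is 300 nM with a range from 100 nM to 1200 nM.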

Compound 4, half-maximal effective concentration: 44 nM
Compound 4: middle estimate off by 6.8-fold (0.83 log units), on the high side; measured number below the stated range.
By their numbers in this assay, from the lowest: compounds 4 and 1 (each within the scatter of the next); then compound 3; then compound 2.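

In this assay, methyl on this aromatic carbon, ortho to a fused ring and meta to the methylsulfonyl group, gives a 1.5-fold lower number from compound 1 to compound 4 (0.19 log units; within the scatter). The same group at another aromatic carbon of the shared core gave an 11-fold higher number from compound 1 to compound 2 (1.05 log units; beyond the scatter), so among these compounds the outcome of adding methyl depends on which carbon carries it. Nothing measured here explains that difference.

The compounds shown leave open whether an ethyl or methoxy group at this same carbon would also stay within the scatter of compound 1.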